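Swapping a nitrophenyl for a methylthiazolyl on the dienone chain

This account rests on a few compounds, and the source may have more. Where it says the series, first, only, none or still open, it means among the compounds named here.

Compound 1 `COc1cc(OC)c2c(=O)c(OCCCOc3ccccc3/C=C/C(=O)/C=C/c3ccccn3)c(-c3cc(OC)c(OC)c(OC)c3)oc2c1`: in a functional assay on U-87MG ATCC cells for antiproliferative activity against U-87 MG (Homo sapiens), read by MTT assay, with a stated time of 48 h (on this read-out higher numbers stand for weaker inhibition and lower numbers for stronger inhibition), compound 1 gives 3930 nM.
Compound 2 `COc1cc(OC)c2c(=O)c(OCCCOc3ccccc3/C=C/C(=O)/C=C/c3cccc([N+](=O)[O-])c3)c(-c3cc(OC)c(OC)c(OC)c3)oc2c1`: in this assay compound 2 gives 7920 nM.

Within the data shown here, compound 2 shows the higher of the two numbers in this assay, but its only neighbour is compound 1, and the step of a 2.0-fold higher number from compound 1 to compound 2 (0.30 log units; within the scatter) stays within the scatter, so the two compounds cannot be put in order. Compound 3 `COc1cc(OC)c2c(=O)c(OCCCOc3ccccc3/C=C/C(=O)/C=C/c3scnc3C)c(-c3cc(OC)c(OC)c(OC)c3)oc2c1` has not yet been measured. It differs from compound 2 by 4-methyl-1,3-thiazol-5-yl in place of 3-nitrophenyl on a double-bonded chain carbon bound to a double-bonded chain carbon. Among the measured compounds shown here, the single measured step that touches this place, a 2.0-fold higher number from compound 1 to compound 2 (0.30 log units; within the scatter), exchanged one aromatic ring for another on the same chain carbon and shifted the number by no more than the scatter. A further ring exchange at the same place is therefore expected to change little. For compound 3 the expected step is a 1.4-fold lower number from compound 2 to compound 3 (0.16 log units; within the scatter). Compound 3 is expected to give about 5500 nM in this assay, within a range from 2500 nM to 12000 nM.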

Compound 3, half-maximal inhibitory concentration: 9630 nM
Compound 3: middle estimate off by 1.8-fold (0.24 log units), on the low side; the range from low to high includes it.
By their numbers in this assay, from the lowest: compounds 1, 2 and 3 (each within the scatter of the next, the first and the last beyond it).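

Among these compounds, the exchange of 3-nitrophenyl for 4-methyl-1,3-thiazol-5-yl gives a 1.2-fold higher number from compound 2 to compound 3 (0.08 log units; within the scatter) in this assay, so a five-membered aromatic ring with 2 hetero atoms cannot be told apart here from a six-membered aromatic ring of carbon only that bears a nitro group. Among the compounds shown here, the same ring also gives the first step at this chain carbon that clears the scatter, a modest 2.5-fold higher number from compound 1 to compound 3 (0.39 log units; beyond the scatter), with the pyridin-2-yl ring on the side of the lower number. Nothing shown here explains why that one gap opens.

As far as these compounds go, all three compounds carry an aromatic ring at this place, so what a saturated ring such as cyclohexyl would do remains open. From the compounds shown here alone, it is also open whether an amine or a carboxylic acid on the ring would move the number further than these exchanges did.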